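A few compounds are considered here, and "the series" means these few. Any claim that something is new, unique, unknown or untested is made for them only; others in the source may bear on it.

Measured so far:
- compound 1, `Cc1ccc(S(=O)(=O)NCc2cn(C[C@H](O)[C@H]3OC(=O)C(OCc4ccccc4)=C3OCc3ccccc3)nn2)cc1` — in a functional assay on SW-620 cells (Homo sapiens) for antiproliferative activity, read by MTT assay, with a stated time of 72 h (a lower number here means a stronger inhibitor, a higher number a weaker inhibitor), compound 1 gives 45800 nM
- compound 2, `Cc1ccc(-c2cn(C/C=C3\OC(=O)C(OCc4ccccc4)=C3OCc3ccccc3)nn2)cc1` — in this assay compound 2 gives only a limit, > 100000 nM

Of the compounds shown here, two have been tested in this assay. For the measured compounds named here, compound 1 stands as the only one with an actual number; the other reading is a limit, (the limit of > 100000 nM in this assay, at which 1 of the 2 values shown sits). Going by the values given here, compound 1 itself is a weak inhibitor, and there is no measured pair here that differs in just one place, so no measured step is available to lean on.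

The compound to be measured next is compound 3, `O=C1O[C@H]([C@@H](O)Cn2ccnn2)C(OCc2ccccc2)=C1OCc1ccccc1`. Compared with compound 1, the change is hydrogen in place of (((4-methylphenyl)sulfonyl)amino)methyl on an aromatic carbon. The shared core of compound 1, with its two benzyloxy groups on the lactone and the hydroxy-bearing linker to the five-membered aromatic ring with 3 nitrogen, stays as it is.

With only a weak number for compound 1 and a limit for compound 2, the step from compound 1 to compound 3 is expected to be small, at most a modest loss beyond the scatter, a 1.5-fold higher number from compound 1 to compound 3 (0.18 log units; within the scatter). Compound 3 is therefore estimated at 70000 nM, with a range from 20000 nM to 200000 nM.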

Compound 3, half-maximal inhibitory concentration: > 100000 nM
Compound 3 gave a limit, no number; the forecaster's own chance of this, stated with the estimate: 40%; middle value at least 1.4-fold (0.15 log units) away from the limit.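

In this assay, putting hydrogen in place of the (((4-methylphenyl)sulfonyl)amino)methyl group on an aromatic carbon gives an at least 2.1-fold higher number from compound 1 to compound 3 (0.33 log units; beyond the scatter). This shows that the group on this carbon of the five-membered aromatic ring with 3 nitrogen matters: with the rest of compound 1 unchanged, losing it takes away the weak but measurable activity. The step gives only a lower bound on the loss, as compound 3 carries a limit and not a number: the limit of > 100000 nM in this assay, at which 2 of the 3 values shown sit.

The departing group combines a six-membered aromatic ring of carbon only with a sulfonyl and an amino link, and the compounds shown do not tell which of these parts counts. Going by these compounds, a plain aminomethyl group or a simple benzyl group on this carbon would help to separate them, and it remains open whether any group here could bring the number well under that of compound 1.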